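The source may hold more compounds than are shown below. What is called first, only, known or untested is meant among the compounds shown, and "the series" means these compounds.

Of the compounds shown here, two have so far been measured in a physicochemical assay for lipophilicity; on this read-out lower numbers stand for lower lipophilicity and higher numbers for higher lipophilicity. Compound 1, `COC(=S)NCCn1c([N+](=O)[O-])cnc1C`, gives 0.9. Compound 2, `Cn1c([N+](=O)[O-])cnc1CO`, gives -0.03, the lowest of the two numbers; its nearest neighbour is compound 1, whose number stands higher by a gap beyond the usual scatter. Compound 1 and compound 2 differ in several places at once, so their pair shows only what the two values are, not what any single change does.

Compound 3, `Cn1c([N+](=O)[O-])cnc1C=O`, has not yet been measured. It differs from compound 2 in a single place: formyl in place of hydroxymethyl on an aromatic carbon. In plain words, a formyl takes the place of a hydroxymethyl on an aromatic carbon of the shared core, the carbon that sits between two ring nitrogen atoms.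

Within the data shown here, no measured pair shows this exchange, so nothing in the data fixes its size. The change swaps two heavy atoms for two heavy atoms, and the expected step of a number 0.38 log units higher from compound 2 to compound 3 (beyond the scatter) is upward but small, close to the edge of the scatter. Compound 3 is therefore estimated at 0.35, within a range from 0 to 0.7.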

Compound 3, partition coefficient: 0.69
Compound 3: middle estimate off by 0.34 log units, on the low side, within the range that was stated.
By their numbers in this assay, from the lowest: compound 2; then compounds 3 and 1 (each within the scatter of the next).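

In this assay, among these compounds, placing formyl instead of hydroxymethyl on the aromatic carbon between two ring nitrogen atoms gives a number 0.72 log units higher from compound 2 to compound 3 (beyond the scatter), the first change at a single place whose size can be read from these data. The step shows that this position responds to the exchange even though the entering and leaving groups have the same heavy-atom count, 2 heavy atoms each (1 carbon, 1 oxygen); what differs by count is that hydroxymethyl carries a hydrogen-bond donor, while formyl carries none and has a double bond outside the aromatic ring. No measurement shown here accounts for the size of this step.

This single pair leaves open how the number would move with an amine, a carboxylic acid or a longer chain on the same carbon, and so whether formyl and hydroxymethyl sit near the ends of what this position can show or close together within a wider spread. It also leaves open whether the same exchange would give a step of similar size on an aromatic carbon elsewhere, or on a core bearing a different group in place of the methyl group.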